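The source may hold more compounds than are shown below. What is called first, only, known or untested is meant among the compounds shown, and "the series" means these compounds.

Working notes on the series. Compound 1 `Cc1cccc(Cn2cc(COc3ccc4c(=O)ccoc4c3)nn2)c1`, compound 2 `O=c1ccoc2cc(OCc3cn(Cc4cccc(Br)c4)nn3)ccc12` and compound 3 `O=c1ccoc2cc(OCc3cn(Cc4ccc(F)cc4)nn3)ccc12` share one core and differ only in the aryl group on a saturated chain carbon bound to an aromatic nitrogen. In a functional assay on QGY7701 cells (Homo sapiens) for cytotoxicity, read by MTT assay, with a stated time of 48 h (on this read-out lower numbers stand for stronger inhibition and higher numbers for weaker inhibition), compound 1 gives 22400 nM, compound 2 gives 17600 nM and compound 3 gives 14400 nM. Compound 3 stands at the lowest of the three numbers shown, but the gaps are small: a 1.6-fold lower number from compound 1 to compound 3 (0.19 log units; within the scatter), a 1.2-fold lower number from compound 2 to compound 3 (0.09 log units; within the scatter), and between the other two a 1.3-fold lower number from compound 1 to compound 2 (0.10 log units; within the scatter). No change at this place has yet moved the read-out beyond scatter.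

Compound 4 `O=c1ccoc2cc(OCc3cn(Cc4cccc([N+](=O)[O-])c4)nn3)ccc12` is not yet measured. It differs from compound 3 by 3-nitrophenyl in place of 4-fluorophenyl on a saturated chain carbon bound to an aromatic nitrogen. All three measured steps alter the same aryl group at the same place and each stayed within scatter, so in this assay no step beyond scatter is expected from compound 3 to compound 4, with the caveat that a 3-nitrophenyl group has not appeared in this set before. The estimate for compound 4 in this assay is 15000 nM, with an expected range from 6000 nM to 40000 nM. This estimate corresponds to an expected step of a 1.0-fold higher number from compound 3 to compound 4 (0.02 log units; within the scatter).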

Compound 4, half-maximal inhibitory concentration: 14100 nM
Beside the measured number, compound 4's estimate is 1.1-fold (0.03 log units) above it; low and high end bracket the measured number.
By their numbers in this assay, from the lowest: compounds 4, 3, 2 and 1 (each within the scatter of the next).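

At the saturated chain carbon bound to an aromatic nitrogen, 3-nitrophenyl, which unlike 4-fluorophenyl carries hydrogen-bond acceptors, leaves the read-out in this assay unmoved beyond the scatter, with a 1.0-fold lower number from compound 3 to compound 4 (0.01 log units; within the scatter). Nitro in place of bromo on an aromatic carbon gives a 1.2-fold lower number from compound 2 to compound 4 (0.10 log units; within the scatter), and the same nitro group set against methyl gives a 1.6-fold lower number from compound 1 to compound 4 (0.20 log units; within the scatter). All four aryl groups shown therefore stand within the scatter of one another, and no measurement shown bears on why this read-out stays so level.

On these data alone, whether an amine, a carboxylic acid or a longer chain at this place would move the read-out beyond the scatter remains open. Also open, as far as these compounds go, is whether any change to the shared core would do so, since all four compounds carry the same core.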